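One Chloro Fewer: Expected Cytotoxicity of Compound 3

The source may report more compounds than this note shows. Statements on the series, on what has been measured and on what is new or still open speak of the compounds shown alone.

Measured so far:
compound 1 `ClCc1ccc(Cn2cnc3nc(Cl)nc(Cl)c32)cc1` – 5620 nM
compound 2 `ClCc1ccccc1Cn1cnc2nc(Cl)nc(Cl)c21` – "not determined" (no result reported)

Compound 1 gives 5620 nM in a functional assay on UO-31 cells (Homo sapiens) for cytotoxicity, read by sulforhodamine B assay, with a stated time of 48 h; on this read-out lower numbers stand for higher toxicity in this test and higher numbers for lower toxicity in this test. Compound 2 has no result reported in this assay, its entry reading "not determined" (no result reported). Compound 1 therefore stands as the only number shown, with one further entry carrying no value, so there is no measured step between compounds to lean on.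

Compound 3 `ClCc1ccc(Cn2cnc3ncnc(Cl)c32)cc1` differs from compound 1 in one place: hydrogen in place of chloro on an aromatic carbon. The change leaves the other chloro group on the shared core untouched and removes a single chlorine from a carbon between two ring nitrogen atoms. Going by the values given here, no pair of measured compounds shows what such a change does to the lethal-concentration read-out in this assay, and compound 2 offers no number for comparison.

With only compound 1 to go on, a modest loss of toxicity is expected, that is a somewhat higher concentration, and the step from compound 1 to compound 3 is estimated at a 1.6-fold higher number from compound 1 to compound 3 (0.20 log units; within the scatter). For compound 3 the estimate is 9000 nM, with a range from 3000 nM to 30000 nM.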

Compound 3, concentration lethal to 50% of the cells: > 100000 nM
Compound 3: no number, only a limit; the forecaster's own chance of this, stated with the estimate: 20%; at least 11-fold (1.04 log units) between middle value and limit.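

The carbon between two ring nitrogen atoms turns out to matter a great deal in this series: hydrogen in place of chloro there gives an at least 17-fold higher number from compound 1 to compound 3 (1.25 log units; beyond the scatter), so the read-out responds strongly to this single chlorine. In this assay, compound 3 gives > 100000 nM, which is a limit of the assay and not a number, so the size of the step is bounded on one side only. Compound 3 keeps the other chloro group on the shared core, meta to the changed carbon, yet that group alone does not bring its value down to a measured number, and the result ends at the top of the range: the limit of > 100000 nM in this assay, at which 1 of the 3 values shown sits.

From the compounds shown here alone, what stays open is how far past the limit the true value of compound 3 lies, and whether any replacement of this chloro would have the same outcome or whether an amine, a methoxy group or a methyl group at the same carbon would keep some of the toxicity of compound 1. Equally open, going by these compounds, is what an amine in place of the remaining chloro group would do, with the chloro between the two ring nitrogen atoms kept.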